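Replacing 3-chlorophenyl by 4-fluorophenyl on a second core

The source may report more compounds than this note shows. Statements on the series, on what has been measured and on what is new or still open speak of the compounds shown alone.

Compound 1 `O=C1C2CCCCN2C(=O)N1CN1CCN(c2cccc(Cl)c2)CC1` and compound 2 `O=C1C2CCCCN2C(=O)N1CN1CCN(c2ccc(F)cc2)CC1` share one core; compound 3 `O=C1C2CCCN2C(=O)N1CCN1CCN(c2cccc(Cl)c2)CC1` and compound 4 `O=C1C2CCCN2C(=O)N1CCN1CCN(c2ccc(F)cc2)CC1` share another. Compound 3 has the same atoms as compound 1, joined differently, and the difference between the two cores is not broken down here.

In an assay on isolated protein for binding affinity to Adrenergic receptor alpha-1 (Rattus norvegicus), read by radioligand binding (on this read-out higher numbers stand for weaker inhibition and lower numbers for stronger inhibition), compound 1 gives 135 nM, while compound 2 gives 869 nM. The change from compound 1 to compound 2 is 4-fluorophenyl in place of 3-chlorophenyl on an amine nitrogen in a ring, and it produced a 6.4-fold higher number from compound 1 to compound 2 (0.81 log units; beyond the scatter).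

In this assay compound 3 gives 500 nM. This number sits within the scatter of that for compound 2 and is beyond the scatter of that for compound 1, on the weaker side.

The change from compound 3 to compound 4 is 4-fluorophenyl in place of 3-chlorophenyl on an amine nitrogen in a ring. Within the data shown here, the place is the same, word for word, as in the move from compound 1 to compound 2, so this is the same change made on the other core; it occurs twice among the compounds here, and only one instance has been measured.

For compound 4 the step is expected to be about a 6.0-fold higher number from compound 3 to compound 4 (0.78 log units; beyond the scatter), set beside the earlier one. That expectation rests on a single instance, the move from compound 1 to compound 2, which gave a 6.4-fold higher number from compound 1 to compound 2 (0.81 log units; beyond the scatter); with one example only, the range is kept wide.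

Compound 4 is therefore expected to give about 3000 nM in this assay, with a range from 1000 nM to 9000 nM.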

Compound 4, inhibition constant: > 1000 nM
Compound 4 gave a limit, no number (the forecaster's own chance of this, stated with the estimate: 5%); the middle value lies beyond the limit too.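

In this assay compound 4 gives > 1000 nM, which is a limit of the assay and not a number. On the core of compound 3, 4-fluorophenyl in place of 3-chlorophenyl therefore reads only as an at least 2.0-fold higher number from compound 3 to compound 4 (0.30 log units; that floor lies within the scatter), which fits a loss of binding on this second core but does not fix its size, and the floor alone does not establish a step beyond the usual scatter. The result is thus compatible with the change carrying over from one core to the other, but it does not show that the step keeps its size, and the comparison remains unresolved: the same change on two cores in this assay, a 6.4-fold higher number (0.81 log units; beyond the scatter) from compound 1 to compound 2 and an at least 2.0-fold higher number (0.30 log units; that floor lies within the scatter) from compound 3 to compound 4; the limit leaves it open whether they differ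

A measured number for compound 4 would be needed to settle whether the two cores respond to this change to the same extent, and two cores with a single pair each could not support a rule for the wider series in any case. On these data alone, each pair also swaps the halogen and its place on the phenyl ring together, so it stays open which of the two matters, and how a plain phenyl or a methoxyphenyl group on the same amine nitrogen would behave on either core.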